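A Heteroaryl Swap on the Carbonyl Carbon

The source may report more compounds than this note shows. Statements on the series, on what has been measured and on what is new or still open speak of the compounds shown alone.

Compound 1 `COc1ccc(/C=C/C(=O)c2cccs2)c(CN2CCCCC2)c1O`: 2.02 ug/mL
Compound 2 `COc1ccc(/C=C/C(=O)c2ccco2)c(CN2CCCCC2)c1O`: 3.07 ug/mL

In a functional assay on PC-3 cells (Homo sapiens) for cytotoxicity, read by sulforhodamine B assay, with a stated time of 3 days (on this read-out lower numbers stand for an effect already at smaller amounts and higher numbers for an effect only at larger amounts of compound), compound 2 gives 3.07 ug/mL, the highest of the two numbers, with compound 1 as its nearest neighbour. Going by the values given here, the one measured step, a 1.5-fold higher number from compound 1 to compound 2 (0.18 log units; within the scatter), lies within the scatter. Compound 3 `COc1ccc(/C=C/C(=O)c2cccnc2)c(CN2CCCCC2)c1O` differs from compound 2 by pyridin-3-yl in place of furan-2-yl on a carbonyl carbon. Among the compounds with values here, that earlier step is the only one bearing on this change, and it exchanged one five-membered ring for another on the same carbonyl carbon without a shift beyond the scatter. The expected change in this assay is therefore a 1.0-fold higher number from compound 2 to compound 3 (0.02 log units; within the scatter). Compound 3 is estimated at 3.2 ug/mL, ranging from 1.5 ug/mL to 7 ug/mL.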

Compound 3, half-maximal effective concentration: 6.77 ug/mL
Compound 3: the middle estimate sits 2.1-fold (0.33 log units) below what was measured, and the stated range covers the measured number.
By their numbers in this assay, from the lowest: compounds 1 and 2 (each within the scatter of the next); then compound 3.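

In this assay, this position on the carbonyl carbon now shows a change beyond the scatter, which the swap between the two five-membered rings did not: the step is a 2.2-fold higher number from compound 2 to compound 3 (0.34 log units; beyond the scatter) and, measured against the thiophen-2-yl compound, a 3.4-fold higher number from compound 1 to compound 3 (0.53 log units; beyond the scatter). Pyridin-3-yl thus stands apart from both furan-2-yl and thiophen-2-yl here, though only modestly. Nothing available here accounts for this shift. The compounds shown cannot separate ring size from the kind of hetero atom, and how phenyl or a simple methyl would read on the same carbonyl carbon remains open.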